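Changing the aryl group on the carbonyl in a guanidine series

The compounds below may be only part of what the source reports. "The series", "measured", "known", "first", "only" and "open" are said of these compounds alone.

Measured compounds:
compound 1, `N=C(N)N/N=C/c1ccc(/C=C/C(=O)c2cccc(Cl)c2)cc1`, 80.7%
compound 2, `Cc1ccc(C(=O)/C=C/c2ccc(/C=N/NC(=N)N)cc2)c(C)c1`, 64.2%

Both compounds were tested in a functional assay on the whole organism (Ear) for inhibition, with Mus musculus as the target, with a stated time of 30 min, at a dose of 100 mg/kg by the intraperitoneal route; on this read-out higher numbers stand for more inhibition at the one dose given (going by the name of the read-out) and lower numbers for less inhibition. Compound 2 stands lowest of the two numbers; its nearest neighbour is compound 1, and the only step shown, a number 16.5 percentage points lower from compound 1 to compound 2 (beyond the scatter), was called modest and lies beyond the scatter. Compound 3, `N=C(N)N/N=C/c1ccc(/C=C/C(=O)c2ccccc2F)cc1`, has not been measured. It differs from compound 2 in one place: 2-fluorophenyl in place of 2,4-dimethylphenyl on a carbonyl carbon. For the measured compounds named here, the one step that bears on this change is the same aryl swap at the carbonyl carbon, where a halogen-bearing phenyl in compound 1 gave the higher number. Going by the values given here, on that basis, the step from compound 2 to compound 3 is expected to go upward, roughly a number 9.8 percentage points higher from compound 2 to compound 3 (within the scatter), though only one comparison supports this. Compound 3 is therefore estimated to give 74%, with a likely range from 56% to 90%.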

Compound 3, a percentage reported as inhibition, in the whole organism at one dose (the size of the read-out at that dose, not a potency): 91.7%
Compound 3: middle estimate off by 17.7 percentage points, on the low side; measured number outside the range, above it.
By their numbers in this assay, from the lowest: compound 2; then compound 1; then compound 3.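

In this assay, 2-fluorophenyl in place of 2,4-dimethylphenyl on the carbonyl carbon gives a number 27.5 percentage points higher from compound 2 to compound 3 (beyond the scatter), so both halogen-bearing phenyl groups shown now stand above the one dimethyl-substituted group, with no compound here going against that. The new compound also separates the two halogen-bearing groups: 2-fluorophenyl in place of 3-chlorophenyl gives a number 11 percentage points higher from compound 1 to compound 3 (beyond the scatter), so the read-out at this position depends on more than the presence of a halogen. Nothing shown here explains either difference.

Since 2-fluorophenyl and 3-chlorophenyl differ in both the halogen and its numbered ring position, these compounds cannot show which of the two matters. As far as these compounds go, how an unsubstituted phenyl or a 4-methoxyphenyl group would compare on this carbonyl carbon also remains open.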